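A few compounds are considered here, and "the series" means these few. Any claim that something is new, unique, unknown or untested is made for them only; others in the source may bear on it.

In a functional assay on MDA-MB-231 cells (Homo sapiens) for cytotoxicity, read by MTT assay, with a stated time of 72 h (on this read-out higher numbers stand for weaker inhibition and lower numbers for stronger inhibition), compound 1 (`O=C1c2c[n+]([O-])c3ccccc3c2C(=O)c2c1c1ccccc1n2Cc1cn([C@@H]2C[C@H](O)[C@@H](CO)O2)nn1`) gives 130 nM and compound 2 (`CC1(C)OCC(Cn2cc(Cn3c4c(c5ccccc53)C(=O)c3c[n+]([O-])c5ccccc5c3C4=O)nn2)O1`) gives 230 nM as its reading. Compound 3 (`CN1CCN(CCCCn2c3c(c4ccccc42)C(=O)c2c[n+]([O-])c4ccccc4c2C3=O)CC1`) gives 110 nM on the same measure. That reading lies within the usual scatter of compound 1 and lower than compound 2, just beyond the scatter.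

Compound 4 (`O=C1c2c[n+]([O-])c3ccccc3c2C(=O)c2c1c1ccccc1n2CCCCN1CCCCC1`) has not yet been measured. It differs from compound 3 in one group (piperidin-1-yl in place of 4-methylpiperazin-1-yl on a saturated chain carbon, four bonds along the chain from an aromatic nitrogen), on a saturated chain carbon, four bonds along the chain from an aromatic nitrogen.

For the measured compounds named here, no measured pair makes this same swap. Going by the values given here, the only measured step between two closely matched compounds changes a different group on an aromatic nitrogen: a 1.8-fold higher number from compound 1 to compound 2 (0.25 log units; within the scatter) stays within the scatter. This is thin, indirect evidence, but it gives no reason to expect a large change. The expected step is a 1.1-fold higher number from compound 3 to compound 4 (0.04 log units; within the scatter) in this assay and is not expected to go beyond the scatter in either direction. For compound 4 the estimated value is 120 nM with an expected range from 50 nM to 300 nM as the likely span.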

Compound 4, half-maximal inhibitory concentration: 610 nM
For compound 4 the middle estimate is 5.1-fold (0.71 log units) below the measured one, outside the stated range (above it).
By their numbers in this assay, from the lowest: compounds 3, 1 and 2 (each within the scatter of the next, the first and the last beyond it); then compound 4.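

In this assay, for the compounds shown here, the group on a saturated chain carbon, four bonds along the chain from an aromatic nitrogen, proves not to be a free choice: piperidin-1-yl in place of 4-methylpiperazin-1-yl gives a 5.5-fold higher number from compound 3 to compound 4 (0.74 log units; beyond the scatter) and so goes beyond the scatter, which the one earlier step did not. The swap is small on paper, as one six-membered non-aromatic ring with 2 hetero atoms gives way to one with 1 hetero atom, so a modest edit at this position can shift the reading. The data at hand offer no measurement that accounts for this step.

Still open, going by these compounds, is whether the second ring nitrogen or its methyl matters here, which unsubstituted piperazin-1-yl or morpholin-4-yl on the same chain could separate. On these data alone, it is also open whether the step between these two rings keeps its size on a longer chain.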